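The source may report more compounds than this note shows. Statements on the series, on what has been measured and on what is new or still open speak of the compounds shown alone.

Series notes. Compound 2 `Cc1cc(CNc2ncnc3c2ncn3[C@@H]2O[C@H](CO)[C@@H](O)[C@H]2O)ccc1[N+](=O)[O-]` stands at the lower of the two numbers obtained so far in an assay on isolated protein for binding affinity to Equilibrative nucleoside transporter 1 (Homo sapiens) (on this read-out lower numbers stand for stronger inhibition and higher numbers for weaker inhibition), where compound 2 gives 87.1 nM. Its nearest neighbour is compound 1 `Cc1c(CNc2ncnc3c2ncn3[C@@H]2O[C@H](CO)[C@@H](O)[C@H]2O)cccc1[N+](=O)[O-]`, which in this assay gives 427 nM; the step of a 4.9-fold lower number from compound 1 to compound 2 (0.69 log units; beyond the scatter) is the only measured one in the set. The next compound is compound 3 `O=[N+]([O-])c1cc(CNc2ncnc3c2ncn3[C@@H]2O[C@H](CO)[C@@H](O)[C@H]2O)ccc1Cl`, which differs from compound 2 by 4-chloro-3-nitrophenyl in place of 3-methyl-4-nitrophenyl on a saturated chain carbon bound to a nitrogen on an aromatic ring. Among the measured compounds shown here, the one measured step changed the arrangement of the methyl and nitro groups on the same ring, not the exchange of a methyl group for a chlorine, so it bears on the new change only loosely. With a single step to go on and no direct analogy, the expectation for compound 3 in this assay is a step of about a 1.0-fold higher number from compound 2 to compound 3 (0.01 log units; within the scatter), hardly beyond the scatter. Compound 3 is therefore estimated at 90 nM, with a range of 30 nM to 300 nM.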

Compound 3, half-maximal inhibitory concentration: 708 nM
Estimate against measurement, compound 3: 7.9-fold (0.90 log units) below, and the stated range ends below it.
By their numbers in this assay, from the lowest: compound 2; then compounds 1 and 3 (each within the scatter of the next).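

In this assay the aryl group on a saturated chain carbon bound to a nitrogen on an aromatic ring proves sensitive to an exchange that leaves the heavy-atom count unchanged: 4-chloro-3-nitrophenyl in place of 3-methyl-4-nitrophenyl gives a clear loss (an 8.1-fold higher number from compound 2 to compound 3 (0.91 log units; beyond the scatter)). 4-Chloro-3-nitrophenyl in place of 2-methyl-3-nitrophenyl gives only a small difference (a 1.7-fold higher number from compound 1 to compound 3 (0.22 log units; within the scatter)), so among these three groups 3-methyl-4-nitrophenyl alone stands apart. Nothing at hand bears on the reason for this result.

As far as these compounds go, the step from 3-methyl-4-nitrophenyl to 4-chloro-3-nitrophenyl alters two substituents at once, so it remains open whether the chlorine or the changed nitro placement accounts for it. Also open, from the compounds shown here alone, is how an amine or a carboxylic acid in place of the nitro group would read in this assay on this aryl group.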